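This account rests on a few compounds, and the source may have more. Where it says the series, first, only, none or still open, it means among the compounds named here.

Three compounds have been measured in an ADME assay for permeability, using PAMPA, with a stated time of 30 min, at pH 7.4; on this read-out higher numbers stand for higher permeability and lower numbers for lower permeability:
compound 1 `CC(C)Cc1ccc2c(NCCCNCc3ccco3)ccnc2c1` gives 23 10^-6 cm/s;
compound 2 `COc1ccc(F)cc1CNCCCNc1ccnc2cc(CC(C)C)ccc12` gives 23 10^-6 cm/s;
compound 3 `COc1cccc(CNCCCNc2ccnc3cc(Oc4ccc(C(C)(C)C)cc4)ccc23)c1O` gives 317 10^-6 cm/s.

Compound 1 stands level with compound 2 at the digits shown, and these two together are the lowest of the three numbers; compound 3 is the furthest away, with a much higher value that lies beyond the scatter. Going by the values given here, the only step measured between compounds differing in a single place, no change at the digits printed from compound 1 to compound 2 (within the scatter), exchanges the group on a saturated chain carbon bound to an amine nitrogen and leaves the read-out unchanged within the scatter.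

Compound 4 `COc1cccc(Oc2ccc3c(NCCCNCc4ccco4)ccnc3c2)c1` has not yet been measured. It differs from compound 1 on the core: 3-methoxyphenoxy in place of isobutyl on an aromatic carbon. Among the compounds with values here, no measured single-place step touches this part of the molecule. The step from compound 1 to compound 2 bears on it only indirectly, showing that a change at the chain end moved nothing. Compound 3, which differs from compound 1 in more than one place, gives a far higher number, and this is the only hint available for a larger group on the core. A rise in this assay is therefore expected, a 5.2-fold higher number from compound 1 to compound 4 (0.72 log units; beyond the scatter). Compound 4 is estimated at 120 10^-6 cm/s, with a range from 50 10^-6 cm/s to 300 10^-6 cm/s.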

Compound 4, apparent permeability: 317 10^-6 cm/s
The estimate for compound 4 lay 2.6-fold (0.42 log units) below the measured number, outside the stated range (above it).
By their numbers in this assay, from the lowest: compounds 1 and 2 (each within the scatter of the next); then compounds 3 and 4 (each within the scatter of the next).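

Placing 3-methoxyphenoxy in place of isobutyl on an aromatic carbon of the shared core gives a 14-fold higher number from compound 1 to compound 4 (1.14 log units; beyond the scatter) in this assay, a large step that shows this position can strongly change the read-out. Going by these compounds alone, the only earlier single-place step, no change at the digits printed from compound 1 to compound 2 (within the scatter), changed a group on a saturated chain carbon bound to an amine nitrogen and left the number unchanged within the scatter, so this is the first single-place step here to move it. The entering group differs from isobutyl in several ways at once, including its six-membered aromatic ring and its hydrogen-bond acceptors, and nothing here measures which of these differences matters or explains the rise.

A plain phenoxy group or a phenyl group on the same aromatic carbon would help separate the contributions of the methoxy group, the ether oxygen and the ring. On these data alone, it also remains open whether the same exchange on the core would give a similar rise with the 5-fluoro-2-methoxyphenyl group of compound 2 in place of the furan-2-yl group.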